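A few compounds are considered here, and "the series" means these few. Any claim that something is new, unique, unknown or untested is made for them only; others in the source may bear on it.

In a functional assay on HCT-116 cells (Homo sapiens) for inhibition, read by CCK-8 assay, with a stated time of 48 h (a higher number here means a weaker inhibitor, a lower number a stronger inhibitor), compound 3 (`COc1cc(-c2ccnc3cc(-c4ccc(N(C)C)cc4)nn23)cc(OC)c1OC`) gives 2050 nM and sits level with compound 1 (`COc1cc(-c2ccnc3cc(-c4ccc(Cl)cc4)nn23)cc(OC)c1OC`) at 3340 nM while compound 2 (`COc1cc(-c2ccnc3cc(-c4ccc(C)cc4)nn23)cc(OC)c1OC`) stands far lower at 48 nM on this scale. Compound 4 (`CCOC(=O)c1ccc(-c2cc3nccc(-c4cc(OC)c(OC)c(OC)c4)n3n2)cc1`) carries ethoxycarbonyl in place of dimethylamino on an aromatic carbon. Going by the values given here, three measured steps concern this same place. Dimethylamino in place of chloro stayed within the scatter (a 1.6-fold lower number from compound 1 to compound 3 (0.21 log units; within the scatter)), whereas the two steps involving methyl were large (a 70-fold lower number from compound 1 to compound 2 (1.84 log units; beyond the scatter)) and (a 43-fold higher number from compound 2 to compound 3 (1.63 log units; beyond the scatter)). Among the compounds with values here, no measured compound carries ethoxycarbonyl, so the guide is weak, and only compound 2 stands apart so far. No change beyond the scatter is therefore expected, and the estimated move is small (a 1.2-fold higher number from compound 3 to compound 4 (0.09 log units; within the scatter)). For compound 4 the estimated value is 2500 nM with an expected range of 500 nM to 10000 nM in this assay.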

Compound 4, half-maximal inhibitory concentration: > 10000 nM
Compound 4: only a limit was reported; the forecaster's own chance of this, stated with the estimate: 10%; at least 4.0-fold (0.60 log units) between middle value and limit.
By their numbers in this assay, from the lowest: compound 2; then compounds 3 and 1 (each within the scatter of the next). At a limit, above all of these: compound 4.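

In this assay compound 4 gives only a limit, not a number: (the limit of > 10000 nM in this assay, at which 1 of the 4 values shown sits). Even so, ethoxycarbonyl at this position separates from all three earlier groups, with (an at least 4.8-fold higher number from compound 3 to compound 4 (0.68 log units; beyond the scatter)), (an at least 2.9-fold higher number from compound 1 to compound 4 (0.47 log units; beyond the scatter)) and (an at least 200-fold higher number from compound 2 to compound 4 (2.31 log units; beyond the scatter)). Dimethylamino and chloro, level with each other, therefore no longer mark the weak end of this position, and a change here can cost more than either of them does.

Going by these compounds, how far compound 4 lies past its limit stays open. So does whether a carboxylic acid, a methyl ester or a primary amine here would behave like ethoxycarbonyl or like methyl.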